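Urea substituent at the carbonyl: piperidine to dichlorobenzylamine

The source may hold more compounds than are shown below. What is called first, only, known or untested is meant among the compounds shown, and "the series" means these compounds.

The measured compounds:
compound 1 `Cc1cc(NC(=O)Nc2cc(Cl)cc(Cl)c2)ccc1N1CCC(N2CCCC2C)C1`, which in an assay on CHO cells for displacement of a labelled ligand from histamine receptor H3 (Macaca mulatta), read by scintillation counting, with a stated time of 1 h (on this read-out higher numbers stand for weaker inhibition and lower numbers for stronger inhibition), gives 43 nM;
compound 2 `CC(=O)N1CCN(C(=O)Nc2ccc(N3CCC(N4CCCC4C)C3)cc2)CC1`, which in this assay gives 34.1 nM;
compound 3 `CC1CCCN1C1CCN(c2ccc(NC(=O)N3CCCCC3)cc2)C1`, which in this assay gives 6 nM.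

Compound 3 stands lowest of the three numbers in this assay; its nearest neighbour is compound 2, and the furthest is compound 1, both gaps beyond the scatter. Going by the values given here, the one step that has been measured at the carbonyl carbon is a 5.7-fold lower number from compound 2 to compound 3 (0.75 log units; beyond the scatter), a modest change on swapping one saturated ring for another.

Compound 4 `CC1CCCN1C1CCN(c2ccc(NC(=O)NCc3cc(Cl)cc(Cl)c3)cc2)C1` differs from compound 3 by (3,5-dichlorobenzyl)amino in place of piperidin-1-yl on a carbonyl carbon. Among the compounds with values here, no measured step covers this change directly: the only step at the carbonyl compares two saturated rings, whereas compound 4 introduces a dichlorinated aromatic ring with an added hydrogen-bond donor. Compound 1, which also bears a dichlorinated aromatic ring, gives a higher number than compound 3, though it differs in more than one place. An increase of modest size in this assay is therefore expected, with wide uncertainty: the estimated step is a 3.3-fold higher number from compound 3 to compound 4 (0.52 log units; beyond the scatter), and compound 4 is expected to give about 20 nM, within 5 nM to 80 nM.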

Compound 4, inhibition constant: 7.1 nM
Estimate against measurement, compound 4: 2.8-fold (0.45 log units) above; low and high end bracket the measured number.
By their numbers in this assay, from the lowest: compounds 3 and 4 (each within the scatter of the next); then compounds 2 and 1 (each within the scatter of the next).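

In this assay, the carbonyl carbon accepts (3,5-dichlorobenzyl)amino in place of piperidin-1-yl with a 1.2-fold higher number from compound 3 to compound 4 (0.07 log units; within the scatter), even though the entering group brings an aromatic ring of carbon only, a hydrogen-bond donor and more heavy atoms. Measured against 4-acetylpiperazin-1-yl, the same group gives a 4.8-fold lower number from compound 2 to compound 4 (0.68 log units; beyond the scatter), a drop in the number in the same direction as a 5.7-fold lower number from compound 2 to compound 3 (0.75 log units; beyond the scatter), so at this position two quite different groups both stand apart from the acetylpiperazine compound. No measurement shown here gives a reason for this tolerance of the aromatic group.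

The compounds shown leave open whether the chlorine atoms, the benzyl ring or the amide hydrogen contribute anything separately at this position, and plain benzylamino, with no chlorine, or a methyl group on that urea nitrogen, would pull these apart on the core of compound 4. They also leave open how far the carbonyl carbon's tolerance extends, for instance to a longer chain such as phenethylamino or to a ring such as morpholin-4-yl.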